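From 2,4-dimethylphenyl to 2-ethylphenyl on a shared core

The compounds below may be only part of what the source reports. "The series", "measured", "known", "first", "only" and "open" are said of these compounds alone.

Of the compounds shown here, three sharing one core have been measured in a functional assay on MGC-803 cells (Homo sapiens) for antiproliferative activity, read by MTT assay, with a stated time of 48 h; a lower number here means a stronger inhibitor, a higher number a weaker inhibitor. Compound 1 `O=C(Nc1ccccc1)Nc1cccc(CNc2nccnc2Cl)c1` gives 16300 nM, compound 2 `O=C(Nc1ccc(Cl)cc1)Nc1cccc(CNc2nccnc2Cl)c1` gives 4980 nM, and compound 3 `Cc1ccc(NC(=O)Nc2cccc(CNc3nccnc3Cl)c2)c(C)c1` gives 10100 nM. Two steps show where the last of these stands: there is a 1.6-fold lower number from compound 1 to compound 3 (0.21 log units; within the scatter), and there is a 2.0-fold higher number from compound 2 to compound 3 (0.31 log units; beyond the scatter).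

Compound 4 `CCc1ccccc1NC(=O)Nc1cccc(CNc2nccnc2Cl)c1` has the same atoms as compound 3, joined differently: 2-ethylphenyl in place of 2,4-dimethylphenyl on an amide-type nitrogen. In words, 2-ethylphenyl takes the place of 2,4-dimethylphenyl on an amide-type nitrogen.

Going by the values given here, no measured step makes this exact swap, so the guidance is indirect. Among the compounds with values here, the largest step so far is a 3.3-fold lower number from compound 1 to compound 2 (0.51 log units; beyond the scatter), which is modest and comes from adding chloro in place of hydrogen on an aromatic carbon. The step that brought in 2,4-dimethylphenyl in place of phenyl, a 1.6-fold lower number from compound 1 to compound 3 (0.21 log units; within the scatter), does not leave the scatter. On that evidence, no step beyond the scatter is expected in this assay. The expected change is a 1.0-fold lower number from compound 3 to compound 4 (0.00 log units; within the scatter). Compound 4 is estimated at 10000 nM, with an expected range of 4500 nM to 22000 nM.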

Compound 4, half-maximal inhibitory concentration: 9370 nM
Estimate against measurement, compound 4: 1.1-fold (0.03 log units) above, and the stated range covers the measured number.
By their numbers in this assay, from the lowest: compounds 2, 4, 3 and 1 (each within the scatter of the next, the first and the last beyond it).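

In this assay there is a 1.1-fold lower number from compound 3 to compound 4 (0.03 log units; within the scatter), so joining the same atoms differently, as 2-ethylphenyl rather than 2,4-dimethylphenyl on the amide-type nitrogen, gives no change that can be told from the noise of repeated measurements. The two other new steps also stay inside the scatter, with a 1.7-fold lower number from compound 1 to compound 4 (0.24 log units; within the scatter) and a 1.9-fold higher number from compound 2 to compound 4 (0.27 log units; within the scatter), so compound 4 cannot be separated by its number from either the plain phenyl compound or the 4-chlorophenyl compound, even though those two are themselves set apart by a 3.3-fold lower number from compound 1 to compound 2 (0.51 log units; beyond the scatter). Nothing measured here speaks to why these alkyl-bearing rings behave so alike.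

As far as these compounds go, what a longer chain such as butyl, or a different kind of group such as methoxy, an amine or a carboxylic acid, would do on this aromatic ring remains open. Also open, from the compounds shown here alone, is whether any group at this place can move the number further than chloro does in compound 2, which gives 4980 nM, a value still in the micromolar range.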